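Methyl for Methoxy on the Amide Aryl Ring

The source may hold more compounds than are shown below. What is called first, only, known or untested is meant among the compounds shown, and "the series" means these compounds.

Measured in an ADME assay on Vero cells (Chlorocebus sabaeus) for cytotoxicity, read by MTT assay, with a stated time of 72 h; on this read-out lower numbers stand for stronger inhibition and higher numbers for weaker inhibition:
compound 1 `CCCCC(=O)Nc1nnc(-c2ccc([N+](=O)[O-])cc2)s1` gives 278000 nM
compound 2 `O=C(Nc1nnc(-c2ccc([N+](=O)[O-])cc2)s1)c1ccco1` gives 306000 nM
compound 3 `COc1ccc(C(=O)Nc2nnc(-c3ccc([N+](=O)[O-])cc3)s2)cc1` gives 278000 nM

Compound 3 stands level with compound 1 at the digits printed, and together these two hold the lowest numbers of the three; the nearest neighbour of compound 3 is compound 1, with no change at the digits printed from compound 1 to compound 3 (within the scatter), and the furthest is compound 2, with a 1.1-fold lower number from compound 2 to compound 3 (0.04 log units; within the scatter).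

Compound 4 `Cc1ccc(C(=O)Nc2nnc(-c3ccc([N+](=O)[O-])cc3)s2)cc1` differs from compound 3 in one place: methyl in place of methoxy on an aromatic carbon. The three measured steps all exchange the whole group on the carbonyl carbon, and each stays within the scatter: a 1.1-fold higher number from compound 1 to compound 2 (0.04 log units; within the scatter), no change at the digits printed from compound 1 to compound 3 (within the scatter), a 1.1-fold lower number from compound 2 to compound 3 (0.04 log units; within the scatter). Within the data shown here, none of them alters a substituent on the 4-methoxyphenyl ring itself, so the change to compound 4 has no direct precedent among the measured pairs. Among the measured compounds shown here, the only guidance is that broad variation of this amide group has left this assay unmoved, and on that basis a step no larger than the scatter is expected: a 1.0-fold higher number from compound 3 to compound 4 (0.00 log units; within the scatter). Compound 4 is therefore estimated at 280000 nM, with a range from 150000 nM to 520000 nM.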

Compound 4, half-maximal inhibitory concentration: 310000 nM
Beside the measured number, compound 4's estimate is 1.1-fold (0.04 log units) below it, and the stated range covers the measured number.
By their numbers in this assay, from the lowest: compounds 1, 3, 2 and 4 (each within the scatter of the next).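

In this assay, among these compounds, the swap on the aromatic carbon para to a large group is the only change here made on the aryl ring itself rather than to the whole group on the carbonyl carbon, and it gives a 1.1-fold higher number from compound 3 to compound 4 (0.05 log units; within the scatter), so the loss of methoxy, with its one hydrogen-bond acceptor, for methyl, with none, does not register beyond the scatter. Compound 4 also stays within the scatter of the other two compounds, with a 1.0-fold higher number from compound 2 to compound 4 (0.01 log units; within the scatter) and a 1.1-fold higher number from compound 1 to compound 4 (0.05 log units; within the scatter), so 4-methylphenyl joins butyl, furan-2-yl and 4-methoxyphenyl on the carbonyl carbon without any separation among the four. No measurement at hand bears on why the numbers stay so close.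

Going by these compounds, whether an amine or a carboxylic acid on that same aromatic carbon, or a longer chain in place of butyl on the carbonyl carbon, would move the number beyond the scatter remains open. Also open, on these data alone, is whether any change to the shared core would do so, and how these compounds behave in any read-out other than this assay.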